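Moving the chlorine on the benzylsulfanyl arm

The source may hold more compounds than are shown below. What is called first, only, known or untested is meant among the compounds shown, and "the series" means these compounds.

Compound 3 `CC1=C(C(=O)Nc2ccc(F)cc2)C(c2ccc([N+](=O)[O-])cc2)N=C(SCc2ccccc2Cl)N1` gives 21.6% in a functional assay on the whole organism (artery, strain albino) with Rattus norvegicus as the target, with a stated time of 360 min, at a dose of 10 mg/kg by the oral route (on this read-out higher numbers stand for more inhibition at the one dose given (going by the name of the read-out) and lower numbers for less inhibition), the lowest of the three numbers in hand. Compound 1 `COc1ccc(C2N=C(SCc3ccc(Cl)cc3)NC(C)=C2C(=O)Nc2ccc(F)cc2)cc1OC` gives 37.1% and compound 2 `CC1=C(C(=O)Nc2ccc(F)cc2)C(c2ccc([N+](=O)[O-])cc2)N=C(SCc2ccccc2)N1` gives 38.7%; both gaps to compound 3 lie beyond the scatter. Among the compounds with values here, the one single-point step recorded, a number 17.1 percentage points lower from compound 2 to compound 3 (beyond the scatter), sets the scale of what one chlorine did on this arm. Compound 4 `CC1=C(C(=O)Nc2ccc(F)cc2)C(c2ccc([N+](=O)[O-])cc2)N=C(SCc2ccc(Cl)cc2)N1` carries 4-chlorophenyl in place of 2-chlorophenyl on a saturated chain carbon bound to a sulfur; cut one bond further out this reads as 2-chlorobenzyl to 4-chlorobenzyl. Within the data shown here, no measured step covers this move directly; compound 1 also carries a 4-chlorobenzyl group but differs elsewhere, so its value is only a hint. Compound 4 is therefore expected to recover part of the drop, a number 11.4 percentage points higher from compound 3 to compound 4 (beyond the scatter), for an estimated 33% in this assay, within 18% to 48%.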

Compound 4, a percentage reported as inhibition, in the whole organism at one dose (the size of the read-out at that dose, not a potency): 39.7%
Compound 4: the middle estimate sits 6.7 percentage points below what was measured, within the range that was stated.
By their numbers in this assay, from the lowest: compound 3; then compounds 1, 2 and 4 (each within the scatter of the next).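

In this assay the place of the chlorine on the arm counts: 4-chlorophenyl in place of 2-chlorophenyl gives a clear change (a number 18.1 percentage points higher from compound 3 to compound 4 (beyond the scatter)). Set against the unsubstituted benzyl, the 4-chlorobenzyl arm shows no change beyond the scatter (a number 1 percentage points higher from compound 2 to compound 4 (within the scatter)), so the loss seen so far belongs to the 2-chlorobenzyl arm alone, and 4-nitrophenyl in place of 3,4-dimethoxyphenyl on a saturated ring carbon also stays within the scatter (a number 2.6 percentage points higher from compound 1 to compound 4 (within the scatter)). No measurement at hand speaks to why the two chlorine placements part. As far as these compounds go, whether a methoxy group or an amine can stand in for the chlorine on this arm stays open, as does the effect of a phenethyl group in place of the benzyl.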